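This account rests on a few compounds, and the source may have more. Where it says the series, first, only, none or still open, it means among the compounds named here.

Of the compounds shown here, two built on one shared core have been measured in a functional assay on HCT-116 cells (Homo sapiens) for inhibition, read by MTT assay, with a stated time of 48 h; on this read-out higher numbers stand for weaker inhibition and lower numbers for stronger inhibition. Compound 1 `COc1ccc(CN(C(C)=O)c2cc(OC)c(OC)c(OC)c2)cc1O` gives 270 nM in this assay, the lowest of the two numbers. Compound 2 `C/C=C/C(=O)N(Cc1ccc(OC)c(N)c1)c1cc(OC)c(OC)c(OC)c1` gives 300 nM in this assay, which lies within the usual scatter of the number for compound 1, so the two cannot be set apart. Compound 3 `C=C(C)C(=O)N(Cc1ccc(OC)c(O)c1)c1cc(OC)c(OC)c(OC)c1` has not yet been measured. It differs from compound 1 in one place: 1-methylethenyl in place of methyl on a carbonyl carbon. Among the compounds with values here, no measured pair shows this exact step, so its size is not known from the data. Compound 2, which also carries a double bond outside aromatic rings on its carbonyl carbon, gives 300 nM in this assay, a number close to that of compound 1. On that basis the step from compound 1 to compound 3 is expected to be small, a 1.2-fold lower number from compound 1 to compound 3 (0.09 log units; within the scatter), with no change beyond the scatter. Compound 3 is therefore estimated at 220 nM in this assay, with a range from 80 nM to 600 nM.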

Compound 3, half-maximal inhibitory concentration: 200 nM
Compound 3: the middle estimate sits 1.1-fold (0.04 log units) above what was measured, and the stated range covers the measured number.
By their numbers in this assay, from the lowest: compounds 3, 1 and 2 (each within the scatter of the next).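

At the carbonyl carbon whose other neighbour is the amide-type nitrogen, 1-methylethenyl in place of methyl gives a 1.4-fold lower number from compound 1 to compound 3 (0.13 log units; within the scatter) in this assay, so this position accepts a group of three heavy atoms with a double bond outside aromatic rings, with no change beyond the scatter. Within the data shown here, compound 1 and compound 2 differ in more than one place, so this is the first single change that can be read directly at this position. No measured evidence is available to explain this result.

From the compounds shown here alone, whether an amine, a carboxylic acid or a longer chain on this carbonyl carbon would keep the number within the scatter remains open. An isopropyl group in the same place would be needed to separate the effect of the double bond from that of the added carbons.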